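This account rests on a few compounds, and the source may have more. Where it says the series, first, only, none or still open, it means among the compounds named here.

Compound 2 `COc1ccc(C2CC(c3cc(Cl)c(C)cc3O)=NN2c2ccc(S(N)(=O)=O)cc2)cc1OC` gives 5850 nM in a functional assay on NCI-H460 cells (Homo sapiens) for antiproliferative activity, with a stated time of 48 h; a higher number here means a weaker inhibitor of growth, a lower number a stronger inhibitor of growth. Within the data shown here, only two numbers have been measured, and compound 1 `Cc1cc(O)c(C2=NN(c3ccc(S(N)(=O)=O)cc3)C(c3ccccc3Cl)C2)cc1Cl` with 4210 nM lies within the scatter of compound 2. Compound 3 `COc1ccc(C2CC(c3cc(Cl)c(C)cc3O)=NN2c2ccc(S(N)(=O)=O)cc2)c(OC)c1OC` differs from compound 2 by methoxy in place of hydrogen on an aromatic carbon. Among the measured compounds shown here, the one measured step, a 1.4-fold higher number from compound 1 to compound 2 (0.14 log units; within the scatter), exchanged a whole ring substituent and stayed within the scatter; no measured step adds a methoxy to this ring. The step of a 1.0-fold higher number from compound 2 to compound 3 (0.01 log units; within the scatter) is therefore expected to stay within the scatter, in no clear direction. Compound 3 is estimated at 6000 nM, with a range from 3000 nM to 12000 nM.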

Compound 3, concentration for total growth inhibition: 3870 nM
For compound 3 the middle estimate is 1.6-fold (0.19 log units) above the measured one, and the stated range covers the measured number.
By their numbers in this assay, from the lowest: compounds 3, 1 and 2 (each within the scatter of the next).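

In this assay, a third methoxy on the ring, ortho to a large group and ortho to a methoxy group, gives a 1.5-fold lower number from compound 2 to compound 3 (0.18 log units; within the scatter) and stays within the scatter, so this position accepts the added group without a clear shift. The exchange of 2-chlorophenyl for 2,3,4-trimethoxyphenyl gives a 1.1-fold lower number from compound 1 to compound 3 (0.04 log units; within the scatter) and also stays within the scatter. Nothing available explains these results. Going by these compounds, whether an amine or a carboxylic acid at this position, or a longer chain in place of the methoxy, would move the number beyond the scatter remains open.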